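The compounds below may be only part of what the source reports. "The series", "measured", "known", "first", "only" and "open" are said of these compounds alone.

In an ADME assay on L6 cells (Rattus norvegicus) for cytotoxicity, read by resazurin assay, with a stated time of 70 h (on this read-out higher numbers stand for weaker inhibition and lower numbers for stronger inhibition), compound 1 (`COc1cc(NC(C)CCCNC(=O)NNC(=O)/C=C/c2ccc(OC)c(OC)c2)c2ncccc2c1`) gives 37000 nM, and compound 2 (`COc1cc(NC(C)CCCNC(=O)NNC(=O)/C=C/c2ccc(C(F)(F)F)cc2)c2ncccc2c1`) gives 28300 nM. Compound 3 (`COc1cc(NC(C)CCCNC(=O)NNC(=O)NC(CO)(CO)CO)c2ncccc2c1`) has the entry "not determined" (no result reported), so it offers no number to start from. Compound 4 (`COc1cc(NC(C)CCCNC(=O)NNC(=O)Nc2ccc(Cl)cc2)c2ncccc2c1`) is compound 3 with one end group exchanged: 4-chlorophenyl in place of 2-hydroxy-1,1-bis(hydroxymethyl)ethyl on an amide-type nitrogen. The new 4-chlorophenyl sits on an amide-type nitrogen, and the 2-hydroxy-1,1-bis(hydroxymethyl)ethyl group is gone.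

Within the data shown here, only one measured step is available, and it bears on this change only indirectly. It is a 1.3-fold lower number from compound 1 to compound 2 (0.12 log units; within the scatter), a swap of one phenyl group for another at a different place in the molecule. That step stayed within the scatter, which suggests that changing a substituted phenyl end group may matter little here, although two compounds are thin evidence. Among the measured compounds shown here, no step from compound 3 can be predicted without a value for it, so the estimate rests on the values of compound 1 and compound 2. Compound 4 is expected at about 25000 nM, with an estimated range of 8000 nM to 75000 nM.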

Compound 4, half-maximal inhibitory concentration: 91900 nM
Compound 4: the middle estimate sits 3.7-fold (0.57 log units) below what was measured, outside the stated range (above it).
By their numbers in this assay, from the lowest: compounds 2 and 1 (each within the scatter of the next); then compound 4.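

In this assay, putting (4-chlorophenyl)amino on the carbonyl carbon in place of the ethenyl-linked phenyl ends gives a 3.2-fold higher number from compound 2 to compound 4 (0.51 log units; beyond the scatter) and a 2.5-fold higher number from compound 1 to compound 4 (0.40 log units; beyond the scatter). Among these compounds, both steps point toward weaker inhibition of the cells, so this carbonyl carbon tolerates a change that shifts the read-out, whereas the exchange of phenyl substituents among the earlier compounds stayed within the scatter. Nothing available explains the shift.

Each step changes both the link to the ring and the ring's substituent, so a 2-(4-chlorophenyl)ethenyl or a (4-(trifluoromethyl)phenyl)amino group on the same carbonyl carbon would be needed to tell those two changes apart. On these data alone, the step from compound 3 cannot be read, so how the 4-chlorophenyl compares with the 2-hydroxy-1,1-bis(hydroxymethyl)ethyl group remains open.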